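This account rests on a few compounds, and the source may have more. Where it says the series, first, only, none or still open, it means among the compounds named here.

Of the compounds shown here, three built on one shared core have been tested in a functional assay on the whole organism (strain STD-dd) with Mus musculus as the target, in the maximal electroshock model, with a stated time of 2 h; on this read-out lower numbers stand for an effect already at smaller amounts and higher numbers for an effect only at larger amounts of compound. Compound 1 `CCNS(=O)(=O)Cc1noc2ccccc12` gives 39 mg/kg. Compound 2 `CN(C)S(=O)(=O)Cc1noc2ccccc12` gives 37 mg/kg, and compound 3 `CN1CCN(S(=O)(=O)Cc2noc3ccccc23)CC1` gives 57 mg/kg. Among these numbers compound 1 stands second highest, yet its values and those of compound 2 and compound 3 all lie within the usual scatter of one another, so no order can be read among them. Going by the values given here, the only measured step, a 1.1-fold lower number from compound 1 to compound 2 (0.02 log units; within the scatter), is dimethylamino in place of ethylamino on a sulfonyl sulfur and leaves the ring untouched. Compound 4 `CCNS(=O)(=O)Cc1noc2ccc(F)cc12` differs from compound 1 in one place: fluoro in place of hydrogen on an aromatic carbon. Among the compounds with values here, no measured step bears on such a ring change, so nothing here speaks for a shift beyond the scatter. Compound 4 is therefore expected to give about 39 mg/kg, between 20 mg/kg and 80 mg/kg, an expected step of no change at the digits printed from compound 1 to compound 4 (within the scatter) in this assay.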

Compound 4, dose for half-maximal effect: 32 mg/kg
The estimate for compound 4 lay 1.2-fold (0.09 log units) above the measured number; measured number inside the range.
By their numbers in this assay, from the lowest: compounds 4, 2, 1 and 3 (each within the scatter of the next).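

Going by these compounds alone, the earlier step touched only the sulfonyl side, so this is the first look at the ring: in this assay fluoro in place of hydrogen on an aromatic carbon gives a 1.2-fold lower number from compound 1 to compound 4 (0.09 log units; within the scatter) and thus no readable change. At this position, then, this single fluoro leaves the dose needed for an effect within the usual scatter. Nothing available explains this result. Going by these compounds, whether a larger group at the same position, such as chloro, methoxy or an amine, would move the number beyond the scatter stays open.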